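Changing an ether side chain on a fast-cleared compound

This account rests on a few compounds, and the source may have more. Where it says the series, first, only, none or still open, it means among the compounds named here.

So far two close relatives have been measured in an ADME assay on the whole organism for pharmacokinetics, with Rattus norvegicus as the target (on this read-out higher numbers stand for fast clearance and lower numbers for slow clearance), and they differ widely. Compound 1 `Cc1cnc(NC(=O)[C@H](COC(C)C)Oc2ncnc3c2cnn3-c2ccccc2Cl)cn1` gives 130 mL/min/kg there, while compound 2 `Cc1ccc(NC(=O)[C@H](COC(C)C)Oc2ncnc3c2cnn3-c2ccccc2Cl)nc1` gives 1400 mL/min/kg as the higher of the two numbers. Within the data shown here, the single measured step runs an 11-fold higher number from compound 1 to compound 2 (1.03 log units; beyond the scatter) and lies beyond the usual scatter, with 5-methylpyridin-2-yl in place of 5-methylpyrazin-2-yl on an amide-type nitrogen. Compound 3 `COCC[C@H](Oc1ncnc2c1cnn2-c1ccccc1Cl)C(=O)Nc1ccc(C)cn1` keeps that amide partner of compound 2 and differs elsewhere: methoxymethyl in place of isopropoxy on a saturated chain carbon, two bonds along the chain from a carbonyl carbon and an oxygen on an aromatic ring is the whole change, which can also be read as isopropoxymethyl to 2-methoxyethyl. Among the measured compounds shown here, no measured step touches this side chain. The large step of an 11-fold higher number from compound 1 to compound 2 (1.03 log units; beyond the scatter) belongs to the amide-type nitrogen and cannot simply be carried over. The expectation in this assay is therefore for no step beyond the scatter, though with a wide margin. The expected change runs a 1.6-fold lower number from compound 2 to compound 3 (0.19 log units; within the scatter) and stays modest. For compound 3 the estimated number is 900 mL/min/kg with an expected range from 300 mL/min/kg to 2200 mL/min/kg until the measurement arrives.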

Compound 3, clearance: 500 mL/min/kg
Compound 3: middle estimate off by 1.8-fold (0.26 log units), on the high side; the measured number falls inside the stated range.
By their numbers in this assay, from the lowest: compound 1; then compound 3; then compound 2.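

In this assay the ether side chain proves able to move the number on its own: methoxymethyl in place of isopropoxy, on a saturated chain carbon, gives a 2.8-fold lower number from compound 2 to compound 3 (0.45 log units; beyond the scatter) and so takes the change past the usual scatter. Among these compounds, this is the first measured step at this position, and it shows that the amide-type nitrogen is not the only place that matters, although the step there, an 11-fold higher number from compound 1 to compound 2 (1.03 log units; beyond the scatter), is the larger of the two. Among the compounds shown here, nothing measured so far explains why the number falls with this side-chain change.

A single step cannot separate the effect of losing the isopropyl end of the chain from that of moving the ether oxygen, since the same change also reads as isopropoxymethyl to 2-methoxyethyl. Going by these compounds, it also remains open whether the 2-methoxyethyl chain would bring a similar fall with the 5-methylpyrazin-2-yl amide of compound 1, and how a longer ether chain, or a chain ending in an amine or a carboxylic acid, would behave here.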